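A few compounds are considered here, and "the series" means these few. Any claim that something is new, unique, unknown or untested is made for them only; others in the source may bear on it.

Measured compounds in a functional assay on CHO-K1 cells for agonist activity at Orexin/Hypocretin receptor type 1 (Homo sapiens), read by FLIPR and calcium flux; a lower number here means that less compound is needed, a higher number that more compound is needed for the effect:

Compound 1 `CC(=O)N1CCC[C@H](NS(C)(=O)=O)[C@@H]1CO[C@H]1CC[C@@H](C(C)C)CC1` gives > 100000 nM, a limit of the assay.
Compound 2 `CC(=O)N1CCC[C@H](NS(=O)(=O)C(C)C)[C@@H]1CO[C@H]1CC[C@@H](C(C)C)CC1` gives > 100000 nM, likewise a limit.
Compound 3 `CC(=O)N1CCC[C@H](NC(=O)O)[C@@H]1CO[C@H]1CC[C@@H](C(C)C)CC1` gives > 100000 nM, again a limit.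

Compound 1 therefore does not stand at a measured number in this assay at all; its value is only a limit, and the same is true of the two other compounds shown. The three changes that connect them, an isopropyl in place of methyl on the sulfonyl sulfur a step that the two limits leave unreadable from compound 1 to compound 2, a carboxy in place of methylsulfonyl on the amine nitrogen a step that the two limits leave unreadable from compound 1 to compound 3, and a carboxy in place of isopropylsulfonyl on the amine nitrogen a step that the two limits leave unreadable from compound 2 to compound 3, are all unreadable in size because of the limit of > 100000 nM in this assay, at which 3 of the 3 values shown sit.

Compound 4 `CC(=O)N1CCC[C@H](NS(C)(=O)=O)[C@@H]1CO[C@H]1CC[C@@H](C)CC1` keeps the methylsulfonyl and the acetyl of compound 1 and alters only the saturated ring: methyl in place of isopropyl on a saturated ring carbon. Among the compounds with values here, none of the measured steps touches this part of the molecule, so no measured step bears directly on it. What the three compounds do show is that trimming or swapping groups on the amine nitrogen left every value at the limit, and the change in compound 4 is also a trimming of a carbon group. The expectation for compound 4 is therefore that the assay again reports only a limit, with no change beyond the scatter, a number no higher from compound 1 to compound 4 (the limit leaves the size open). The estimate for compound 4 is 100000 nM, in the range 30000 nM to 100000 nM.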

Compound 4, half-maximal effective concentration: > 100000 nM
Compound 4 ended at the assay's limit (the forecaster's own chance of this, stated with the estimate: 90%); the middle value sits exactly at the limit.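

No new step can be read from compound 1 to compound 4, the change of isopropyl to methyl on a saturated ring carbon, because both compounds stand at the same limit: the limit of > 100000 nM in this assay, at which 4 of the 4 values shown sit.

The compounds shown leave open what number any of them would give in this assay, and so whether the isopropyl, the methyl or the groups on the amine nitrogen make any difference to the effect.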